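The source may hold more compounds than are shown below. What is called first, only, known or untested is meant among the compounds shown, and "the series" means these compounds.

Measured so far:
compound 1 `COc1cccc2cc(-c3ccccc3)c(O)nc12`, 10000 nM
compound 2 `COc1ccc2cc(-c3ccccc3)c(O)nc2c1`, 10000 nM

In a functional assay on U-87MG ATCC cells for cytotoxicity against U-87 MG (Homo sapiens), read by colorimetric assay and MTT assay (a higher number here means a weaker inhibitor, a lower number a stronger inhibitor), compound 1 gives 10000 nM and compound 2 gives 10000 nM, level with compound 1 within the scatter. Compound 3 `COc1cc(OC)c2cc(-c3ccccc3)c(O)nc2c1` is not yet measured. It differs from compound 2 by methoxy in place of hydrogen on an aromatic carbon, the methoxy entering ortho to a fused ring and meta to the methoxy group already present. Among the measured compounds shown here, with both known compounds at the same reading and no single-point step measured, little shift is expected in this assay: the step of no change at the digits printed from compound 2 to compound 3 (within the scatter) is estimated to stay within the scatter. Compound 3 is expected to give about 10000 nM, within 4000 nM to 25000 nM.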

Compound 3, half-maximal inhibitory concentration: 10000 nM
Compound 3: the middle estimate sits on the measured number at the digits printed, and the stated range covers the measured number.
By their numbers in this assay, from the lowest: compounds 1, 2 and 3 (each within the scatter of the next).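

In this assay there is no change at the digits printed from compound 2 to compound 3 (within the scatter) when methoxy takes the place of hydrogen on an aromatic carbon ortho to a fused ring and meta to a methoxy group. Among the compounds shown here, this is the first single-place step, and it shows that this position carries a second methoxy with the reading unmoved. No measured evidence bears on why the reading holds.

The compounds shown leave open whether an amine, a carboxylic acid or a longer alkoxy chain at this position would move the reading. They also leave open whether any change elsewhere on the shared core would do so.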